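This account rests on a few compounds, and the source may have more. Where it says the series, first, only, none or still open, it means among the compounds named here.

Compound 1 `CCNC(=O)Nc1ccc(/C=C\c2cc(C)cc(C)c2)cc1` gives 17000 nM in a functional assay on MCF7 cells (Homo sapiens) for inhibition, read by sulforhodamine B assay, with a stated time of 48 h; a higher number here means a weaker inhibitor, a lower number a stronger inhibitor. Compound 2 `Cc1cc(C)cc(/C=C\c2ccc(N3CCNC3=O)cc2)c1` differs from it in one place, (2-oxoimidazolidin-1-yl in place of (ethylcarbamoyl)amino on an aromatic carbon), and gives 23 nM, a step of a 740-fold lower number from compound 1 to compound 2 (2.87 log units; beyond the scatter). Compound 3 `CCNC(=O)Nc1ccc(/C=C/c2cc(OC)c(OC)c(OC)c2)cc1` gives 17000 nM in this assay, level with compound 1 at the digits shown; the difference between the two cores is not broken down here. Compound 4 `COc1cc(/C=C/c2ccc(N3CCNC3=O)cc2)cc(OC)c1OC` carries the same change against compound 3, (2-oxoimidazolidin-1-yl in place of (ethylcarbamoyl)amino on an aromatic carbon), at a place described in the same words. The step from compound 3 to compound 4 is expected to be large, resting on a 740-fold lower number from compound 1 to compound 2 (2.87 log units; beyond the scatter), but taken as somewhat smaller, since the two cores differ in an untold way, giving an expected 110-fold lower number from compound 3 to compound 4 (2.05 log units; beyond the scatter). Compound 4 is therefore estimated at 150 nM in this assay, between 20 nM and 2000 nM.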

Compound 4, half-maximal inhibitory concentration: 540 nM
Compound 4: middle estimate off by 3.6-fold (0.56 log units), on the low side, within the range that was stated.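

In this assay, putting 2-oxoimidazolidin-1-yl in place of (ethylcarbamoyl)amino on the second core again gives a large step, a 31-fold lower number from compound 3 to compound 4 (1.50 log units; beyond the scatter). The direction of the change therefore carries over from one core to the other in these two pairs, but its size does not: the same change on two cores in this assay, a 740-fold lower number (2.87 log units; beyond the scatter) from compound 1 to compound 2 and a 31-fold lower number (1.50 log units; beyond the scatter) from compound 3 to compound 4, 23-fold (1.37 log units) apart, beyond the scatter of two such steps

These two pairs do not show what sets the size of the step, and they make no rule for any further core. Still open, from the compounds shown here alone, is how a simple amine or a carboxylic acid on the same aromatic carbon would compare with 2-oxoimidazolidin-1-yl, and whether the step would stay large on a third core.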